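Inverting one stereocentre in a weak inhibitor

The source may hold more compounds than are shown below. What is called first, only, known or untested is meant among the compounds shown, and "the series" means these compounds.

Compound 1 `CCN(CC)S(=O)(=O)c1ccc(S(=O)(=O)N2CCC[C@@H](C(=O)NC3COC3)C2)cc1` gives 2300 nM
Compound 2 `CCOC(=O)[C@H]1CCN(S(=O)(=O)c2ccc(S(=O)(=O)N(CC)CC)cc2)C1` gives 29200 nM

In a functional assay on MIA PaCa-2 cells (Homo sapiens) for inhibition, read by MTT assay, with a stated time of 7 days (a lower number here means a stronger inhibitor, a higher number a weaker inhibitor), compound 2 has the higher number of the two (29200 nM) and is therefore the weaker inhibitor. Compound 1 lies lower (2300 nM), and the gap between them is beyond the usual scatter.

The next compound to be tested is compound 3 `CCOC(=O)[C@@H]1CCN(S(=O)(=O)c2ccc(S(=O)(=O)N(CC)CC)cc2)C1`, which has the same atoms and bonds as compound 2 (the two compounds have the same atoms and bonds and differ only in configuration as drawn: 1 of 1 stereo elements differ; a stereocentre at a saturated ring carbon is drawn S in compound 2 and R in compound 3). A stereocentre at a saturated ring carbon is drawn S in compound 2 and R in compound 3. For the measured compounds named here, no measured pair here differs in only one place, so the data do not show what inverting this centre does.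

With no evidence for either direction, no step beyond the scatter is expected in this assay. The estimated change is a 1.2-fold lower number from compound 2 to compound 3 (0.07 log units; within the scatter) and would leave the two compounds indistinguishable. For compound 3 the expected value is 25000 nM with an estimated range of 8000 nM to 60000 nM as the likely span.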

Compound 3, half-maximal inhibitory concentration: 8600 nM
The estimate for compound 3 lay 2.9-fold (0.46 log units) above the measured number, within the range that was stated.
By their numbers in this assay, from the lowest: compound 1; then compound 3; then compound 2.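

In this assay, for the compounds shown here, the configuration at this saturated ring carbon makes a difference that the earlier compounds could not show, since they offered no pair differing in one place: going from S as drawn to R gives a 3.4-fold lower number from compound 2 to compound 3 (0.53 log units; beyond the scatter). This is a modest step, but it is beyond the scatter, and it can be assigned to this single stereocentre because nothing else separates the two structures: the fact that compounds 2 and 3 differ only in the configuration as drawn. The better of the two configurations still leaves compound 3 at 8600 nM, so inverting this centre alone does not turn the ethyl ester series into a strong inhibitor.

The compounds shown leave open whether R would still give the lower number if the ethyl ester at this carbon gave way to another group, such as a carboxylic acid or a longer chain ester, since this pair tests the inversion with the ethyl ester alone. They also leave open what inverting the stereocentre of compound 1 would do, as that compound carries a different ring and a different group at its stereocentre.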